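Lengthening the amide chain again: from sec-butyl to aminooctyl

A few compounds are considered here, and "the series" means these few. Any claim that something is new, unique, unknown or untested is made for them only; others in the source may bear on it.

Of the compounds shown here, two sharing one core have been tested in an assay on cell membranes for binding affinity to 2-oxoglutarate receptor 1 (Rattus norvegicus), read by radioligand binding; on this read-out lower numbers stand for stronger inhibition and higher numbers for weaker inhibition. Compound 1 `CCCCCCCCNC(=O)[C@H]1OC(n2cnc3c(N)ncnc32)[C@H](O)[C@@H]1O` carries an octyl chain on the amide nitrogen, and in this assay compound 1 gives 21 nM. Compound 2 `CCC(C)NC(=O)[C@H]1OC(n2cnc3c(N)ncnc32)[C@H](O)[C@@H]1O` carries a sec-butyl group in the same place, and in this assay compound 2 gives 198 nM. Among the measured compounds shown here, the single measured step is a 9.4-fold higher number from compound 1 to compound 2 (0.97 log units; beyond the scatter), so compound 2 stands with the higher, weaker number of the two.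

Compound 3 `NCCCCCCCCNC(=O)[C@H]1OC(n2cnc3c(N)ncnc32)[C@H](O)[C@@H]1O` is not yet measured. It differs from compound 2 in one place: 8-aminooctyl in place of sec-butyl on an amide-type nitrogen. This change restores a chain as long as the octyl of compound 1 and adds a terminal amine. Because the step of a 9.4-fold higher number from compound 1 to compound 2 (0.97 log units; beyond the scatter) shows that the long chain went with the lower number, a drop back toward compound 1 is expected for compound 3, estimated as a 5.0-fold lower number from compound 2 to compound 3 (0.69 log units; beyond the scatter). For compound 3 the expected value in this assay is 40 nM, with a range from 10 nM to 200 nM.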

Compound 3, inhibition constant: 29 nM
Estimate against measurement, compound 3: 1.4-fold (0.14 log units) above, and the stated range covers the measured number.
By their numbers in this assay, from the lowest: compounds 1 and 3 (each within the scatter of the next); then compound 2.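

In this assay, 8-aminooctyl in place of sec-butyl on the amide-type nitrogen gives a 6.8-fold lower number from compound 2 to compound 3 (0.83 log units; beyond the scatter) and so shows that the lower number seen with the octyl chain of compound 1 also appears with a second long chain. Amino in place of hydrogen, eight bonds along the chain from the amide-type nitrogen, gives a 1.4-fold higher number from compound 1 to compound 3 (0.14 log units; within the scatter) and so leaves the number within the usual scatter, which means this position tolerates the added amine in this assay. No measurement here gives a reason for either step.

A straight butyl chain could show whether chain length or branching matters more, since sec-butyl differs from the long chains in both. From the compounds shown here alone, the effect of a hydroxyl or a carboxylic acid at the end of the long chain remains open.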